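Chloro in Place of Methyl on Compound 3

A few compounds are considered here, and "the series" means these few. Any claim that something is new, unique, unknown or untested is made for them only; others in the source may bear on it.

Compound 1 `C/C(=C\c1cc(-c2ccc(F)nc2)co1)C(N)=O`: > 50000 nM
Compound 2 `C/C(=C\c1ccc(-c2ccc(F)cc2)o1)C(N)=O`: 1650 nM
Compound 3 `C/C(=C\c1cc(-c2ccc(C)cc2)cs1)C(N)=O`: > 50000 nM

Of the compounds shown here, three have been tested in a functional assay on A549 cells (Homo sapiens) for cytotoxicity, read by CCK-8 assay, with a stated time of 24 h; on this read-out higher numbers stand for weaker inhibition and lower numbers for stronger inhibition. Compound 1 gives only a limit of the assay, > 50000 nM. Compound 3 likewise gives only a limit of the assay, > 50000 nM. Compound 2 alone gives a number, 1650 nM. Compound 3 therefore stands with compound 1 at the limit of > 50000 nM in this assay, at which 2 of the 3 values shown sit, and nothing more than that is known about it; how far it lies from compound 2 cannot be told.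

Compound 4 `C/C(=C\c1cc(-c2ccc(Cl)cc2)cs1)C(N)=O` differs from compound 3 by chloro in place of methyl on an aromatic carbon. Going by the values given here, no pair of measured compounds shows this change, so its effect is unknown. Compound 4 is expected to stay at the same limit as compound 3, with a step from compound 3 to compound 4 of a number no higher from compound 3 to compound 4 (the limit leaves the size open), that is, none beyond the scatter. Compound 4 is thus estimated at 50000 nM, within 15000 nM to 150000 nM.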

Compound 4, half-maximal inhibitory concentration: > 50000 nM
Compound 4 ended at the assay's limit; the forecaster's own chance of this, stated with the estimate: 70%; the middle value lies on the limit itself.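

Compound 3 gives only a limit, > 50000 nM. Going by these compounds alone, compound 4 likewise gives only a limit, > 50000 nM, so no step between compound 3 and compound 4 can be read. The compounds shown leave open what chloro in place of methyl on an aromatic carbon does to this read-out.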